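Swapping methoxy for isopropyl on the outer phenyl ring

This account rests on a few compounds, and the source may have more. Where it says the series, first, only, none or still open, it means among the compounds named here.

Of the compounds shown here, three sharing one core have been tested in an assay on cells for inhibition of Amine oxidase [flavin-containing] B (Homo sapiens), read by fluorescence, with stated times of 30 min and 15 min, tested at 1 uM; on this read-out higher numbers stand for more inhibition at the one concentration tested (going by the name of the read-out) and lower numbers for less inhibition. Compound 1, `COc1ccc(OCCOc2ccc3[nH]c(=O)n(C(C)C)c3c2)cc1`, gives 15.5% in this assay. Compound 2, `CCn1c(=O)[nH]c2ccc(OCCOc3ccc(OC)cc3)cc21`, gives 13.9%, and compound 3, `CC(C)n1c(=O)[nH]c2ccc(OCCOc3cccc(F)c3)cc21`, gives 12.9%. Compound 1 therefore carries the top number of the three shown, but the two steps that lead away from it, a number 1.6 percentage points lower from compound 1 to compound 2 (within the scatter) and a number 2.6 percentage points lower from compound 1 to compound 3 (within the scatter), are both small, so the three numbers cannot be told apart with confidence.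

The next compound, compound 4, is `CC(C)c1ccc(OCCOc2ccc3[nH]c(=O)n(C(C)C)c3c2)cc1`. It differs from compound 1 in one place: isopropyl in place of methoxy on an aromatic carbon. The change sits on the outer phenyl ring, para to a large group.

Neither measured step alters this same position in this same way. The closest comparison is the step from compound 1 to compound 3, where the whole 4-methoxyphenyl was exchanged for 3-fluorophenyl and the number barely moved. Changing a single substituent on that ring is a smaller alteration, so no step beyond the scatter is expected for compound 4 in this assay, which means an expected step of a number 1.5 percentage points lower from compound 1 to compound 4 (within the scatter). The estimate for compound 4 is 14%, within a range from 4% to 26%.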

Compound 4, a percentage reported as inhibition, at one concentration (the size of the read-out at that concentration, not a potency): 14.1%
The estimate for compound 4 lay 0.1 percentage points below the measured number, within the range that was stated.
By their numbers in this assay, from the lowest: compounds 3, 2, 4 and 1 (each within the scatter of the next).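

In this assay, isopropyl in place of methoxy on this aromatic carbon, para to a large group, gives a number 1.4 percentage points lower from compound 1 to compound 4 (within the scatter), so the two compounds cannot be told apart. Unlike the step to compound 3, which also moved the substituent and replaced methoxy with a fluorine, this change keeps the position and alters only the group: the methoxy oxygen, with its 1 hydrogen-bond acceptor, is gone, and the group grows from 2 heavy atoms to 3, yet compound 4 keeps a number in the same narrow band as the others. No measurement is available that would explain why the number holds across this swap.

As far as these compounds go, whether a group of another kind on this carbon, such as an amine or a carboxylic acid, would produce a step beyond the scatter remains open. All four numbers also come from a single concentration and sit close together, so they do not show how potency would compare across these compounds, or whether any substituent at this position matters for it.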